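Aryl ether exchange in the acid series: compound 3 to 4

The source may report more compounds than this note shows. Statements on the series, on what has been measured and on what is new or still open speak of the compounds shown alone.

Working notes. Compound 1 `O=C(O)CC/C=C\CC1COC(c2cccnc2)OC1c1cccnc1` and compound 2 `O=C(O)CC/C=C\CC1COC(c2cccs2)OC1c1cccnc1` share the acid-bearing core and differ in one group on a saturated ring carbon. Among the compounds with values here, in a functional assay for inhibition, with Homo sapiens as the target (a lower number here means tighter binding, a higher number weaker binding), compound 1 gives 759 nM and compound 2 gives 1000 nM; the step of a 1.3-fold higher number from compound 1 to compound 2 (0.12 log units; within the scatter) is the only measured one-place change in the set.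

Compound 3 `Cc1ccc(C#N)c(OC(C)(C)C2OCC(C/C=C\CCC(=O)O)C(c3cccnc3)O2)c1` carries an aryl ether on the saturated carbon that hangs from the core. In this assay compound 3 gives 15.9 nM, the lowest of the three numbers, and its gaps to compound 1 and to compound 2 both lie beyond the scatter.

Compound 4 `COc1ccc(OC(C)(C)C2OCC(C/C=C\CCC(=O)O)C(c3cccnc3)O2)c([N+](=O)[O-])c1` differs from compound 3 in one place: 4-methoxy-2-nitrophenyl in place of 2-cyano-5-methylphenyl on an oxygen on a saturated carbon. Within the data shown here, no measured step touches the aryl on this oxygen; the single step available, from compound 1 to compound 2, concerns the aryl on the saturated ring carbon and was within the scatter, so it gives no guidance on the size or direction of the present change. The expectation for compound 4 in this assay is therefore a number near that of compound 3, with a wide allowance either way, and no step beyond the scatter is expected, a 1.9-fold higher number from compound 3 to compound 4 (0.28 log units; within the scatter). The estimate for compound 4 is 30 nM, within 8 nM to 120 nM.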

Compound 4, dissociation constant: 6.17 nM
Compound 4: middle estimate off by 4.9-fold (0.69 log units), on the high side; the measured number lies below the stated range.
By their numbers in this assay, from the lowest: compound 4; then compound 3; then compounds 1 and 2 (each within the scatter of the next).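

Within the data shown here, the aryl on an oxygen on a saturated carbon is a position where the number in this assay responds to exchange: 4-methoxy-2-nitrophenyl in place of 2-cyano-5-methylphenyl gives a 2.6-fold lower number from compound 3 to compound 4 (0.41 log units; beyond the scatter) and so stands as the only measured one-place step beyond the scatter, whereas the earlier step on a saturated ring carbon, a 1.3-fold higher number from compound 1 to compound 2 (0.12 log units; within the scatter), stayed within it. The entering group has 11 heavy atoms and 3 hydrogen-bond acceptors against 9 and 1 for the leaving group, with one six-membered aromatic ring of carbon only in both, so this position accepts the larger aryl with no rise in the number across this single pair. Nothing available explains the direction or the size of this step.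

The exchange alters the aryl in more than one respect at once, so the compounds shown do not separate the contributions of the nitro and methoxy groups or of the nitrile and methyl groups. Also open, on these data alone, is whether the step would carry over to an aryl with an amine or a trifluoromethyl group at this place, or to a core bearing thiophen-2-yl as in compound 2.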